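A few compounds are considered here, and "the series" means these few. Any claim that something is new, unique, unknown or untested is made for them only; others in the source may bear on it.

Working notes on the series. Compound 1 `Oc1ccc(-c2cc(-c3cccs3)nc(-c3ccccc3Cl)c2)cc1` and compound 2 `Oc1ccc(-c2cc(-c3ccc(Cl)cc3)nc(-c3cccs3)c2)cc1` share a core and differ by one change: 4-chlorophenyl in place of 2-chlorophenyl on an aromatic carbon. In a functional assay on DU-145 cells (Homo sapiens) for cytotoxicity, read by CCK-8 assay and cell counting, with a stated time of 2 days (a lower number here means a stronger inhibitor, a higher number a weaker inhibitor), compound 1 gives 4190 nM, and compound 2 gives 7660 nM; the step of a 1.8-fold higher number from compound 1 to compound 2 (0.26 log units; within the scatter).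

In this assay compound 3 `Oc1cccc(-c2cc(-c3cccnc3)nc(-c3ccccc3Cl)c2)c1` is recorded as "not determined" (no result reported), so no result is reported for it. Compound 4 `Oc1cccc(-c2cc(-c3ccc(Cl)cc3)nc(-c3cccnc3)c2)c1` is not yet measured. The difference between the core of compound 3 and that of compound 1 is not broken down here. The change from compound 3 to compound 4 is the same kind of change as from compound 1 to compound 2, (4-chlorophenyl in place of 2-chlorophenyl on an aromatic carbon); the place differs in being meta to a 3-hydroxyphenyl group and a pyridin-3-yl group rather than a 4-hydroxyphenyl group and a thiophen-2-yl group.

With no number for compound 3, the expectation for compound 4 rests on compound 1 at 4190 nM and compound 2 at 7660 nM, with a small step expected in line with a 1.8-fold higher number from compound 1 to compound 2 (0.26 log units; within the scatter). In this assay compound 4 is estimated at 8000 nM, expected between 2000 nM and 30000 nM.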

Compound 4, half-maximal inhibitory concentration: 26800 nM
For compound 4 the middle estimate is 3.4-fold (0.53 log units) below the measured one; low and high end bracket the measured number.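

Among these compounds, compound 3 carries no number in this assay, so no step from it to compound 4 can be read. The compounds shown leave open whether 4-chlorophenyl in place of 2-chlorophenyl acts on the core of compound 3 as on that of compound 1. No supporting evidence bears on this result.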